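Nitro for hydrogen in two pairs: working notes

The source may hold more compounds than are shown below. What is called first, only, known or untested is meant among the compounds shown, and "the series" means these compounds.

Measured so far:
compound 1, `COc1ccc(Oc2ccccc2-c2ccsc2S(=O)(=O)N2CCN(C(=S)Nc3ccc([N+](=O)[O-])cc3)CC2)cc1OC`: > 50000 nM
compound 2, `COc1ccc(Oc2ccc([N+](=O)[O-])cc2-c2ccsc2S(=O)(=O)N2CCN(C(=S)Nc3ccc([N+](=O)[O-])cc3)CC2)cc1OC`: > 50000 nM
compound 3, `O=S(=O)(c1sccc1-c1ccccc1Oc1ccc(O)c(O)c1)N1CCN(C(=S)Nc2cc(C(F)(F)F)cc(C(F)(F)F)c2)CC1`: 2200 nM

In a functional assay on HL-60 cells (Homo sapiens) for inhibition, read by CCK-8 assay, with a stated time of 48 h (on this read-out lower numbers stand for stronger inhibition and higher numbers for weaker inhibition), compound 1 returns only a limit, > 50000 nM. Compound 2 likewise returns only a limit, > 50000 nM. The change from compound 1 to compound 2 is nitro in place of hydrogen on an aromatic carbon, and the step it made, a step that the two limits leave unreadable from compound 1 to compound 2, cannot be read because both values sit at the limit of > 50000 nM in this assay, at which 2 of the 3 values shown sit. Within the data shown here, compound 3 is the one compound with a number in this assay, giving 2200 nM. How the core of compound 3 differs from the core of compound 1 is not broken down here.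

Compound 4, `O=[N+]([O-])c1ccc(Oc2ccc(O)c(O)c2)c(-c2ccsc2S(=O)(=O)N2CCN(C(=S)Nc3cc(C(F)(F)F)cc(C(F)(F)F)c3)CC2)c1`, is not yet measured. It differs from compound 3 by nitro in place of hydrogen on an aromatic carbon. Among the measured compounds shown here, this is the same kind of change as the one from compound 1 to compound 2, but not the same: in the earlier pair the place is para to a 3,4-dimethoxyphenoxy group, here it is para to a 3,4-dihydroxyphenoxy group. The earlier pair gives no readable size, so no size is carried over from it. For the measured compounds named here, the expectation for compound 4 therefore rests on compound 3 alone, whose value 2200 nM is the only number, and the step is expected to be small, a 1.1-fold higher number from compound 3 to compound 4 (0.06 log units; within the scatter). Compound 4 is thus expected near 2500 nM, within 700 nM to 9000 nM, in this assay.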

Compound 4, half-maximal inhibitory concentration: 8400 nM
Compound 4: the middle estimate sits 3.4-fold (0.53 log units) below what was measured; the measured number falls inside the stated range.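

In this assay, nitro in place of hydrogen on an aromatic carbon, para to a 3,4-dihydroxyphenoxy group, gives a 3.8-fold higher number from compound 3 to compound 4 (0.58 log units; beyond the scatter), so on the core of compound 3 the change costs a modest but readable amount of inhibition. The same kind of change, para to a 3,4-dimethoxyphenoxy group, cannot be read because compound 1 and compound 2 each return only a limit: (the limit of > 50000 nM in this assay, at which 2 of the 4 values shown sit). Carrying the change from one core to another is thus not tested in either direction: one readable pair gives a size for the core of compound 3 alone, and nothing shown says whether a step of that size, or any step, occurs on the core of compound 1.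

The compounds shown leave open whether a different group at this place, such as an amine, a nitrile or a carboxylic acid, would shift the number in this assay as nitro does, or leave it where hydrogen has it. They also leave open whether nitro gives a similar step on any second core whose values are numbers and not limits, and no cause for the step can be named from these data.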